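A few compounds are considered here, and "the series" means these few. Any claim that something is new, unique, unknown or untested is made for them only; others in the source may bear on it.

Of the compounds shown here, three with a shared core have been measured in an ADME assay on S9 fraction from liver (Mus musculus, strain ICR/CD-1) for metabolic stability, read by LC-MS, using NADPH, with a stated time of 5 min, tested at 2 uM; on this read-out higher numbers stand for a longer-lived compound and lower numbers for a shorter-lived compound. Compound 1 `Cc1cc(Cl)cc(Cl)c1S(=O)(=O)N1CCC(N2CCC(C)CC2)CC1` gives 0.12 h, compound 2 `Cc1c(C)c(S(=O)(=O)N2CCC(N3CCC(C)CC3)CC2)c(C)c2c1OC(C)(C)C2` gives 1.12 h, and compound 3 `COc1ccccc1-c1cccc(S(=O)(=O)N2CCC(N3CCC(C)CC3)CC2)c1` gives 0.25 h. Compound 3 therefore stands second of the three, above compound 1 and below compound 2, and both gaps lie beyond the scatter.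

The account now turns to compound 4 `CC1CCN(C2CCN(S(=O)(=O)c3cccc(-c4ccccc4)c3)CC2)CC1`, which carries hydrogen in place of methoxy on an aromatic carbon, so that 2-methoxyphenyl becomes phenyl (hydrogen in place of methoxy on an aromatic carbon). For the measured compounds named here, no two measured compounds differ in one place only, so the data hold no measured step that sizes this change. The expectation therefore rests on compound 3 and its 0.25 h, with only a small move toward a higher number in this assay. The estimated change, a 1.2-fold higher number from compound 3 to compound 4 (0.08 log units; within the scatter), is expected to stay within the scatter. For compound 4 the estimated half-life is 0.3 h, with an expected range from 0.14 h to 0.65 h.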

Compound 4, half-life: 0.517 h
Compound 4: middle estimate off by 1.7-fold (0.24 log units), on the low side, within the range that was stated.
By their numbers in this assay, from the lowest: compound 1; then compound 3; then compound 4; then compound 2.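

In this assay, for the compounds shown here, the change from 2-methoxyphenyl to phenyl gives a 2.1-fold higher number from compound 3 to compound 4 (0.32 log units; beyond the scatter), the first measured step in this set in which two compounds differ in one place only. The step is modest, but it shows that the half-life responds to what sits on this aromatic carbon, ortho to a large group, and that hydrogen there gives the longer-lived compound of this pair. Nothing measured here accounts for the step.

Going by these compounds, whether a fluorine atom, a hydroxyl group or an ethoxy group on this same carbon would fall nearer to hydrogen or to methoxy remains open. On these data alone, it also remains open whether the same exchange would give a step of similar size on a compound that lacks the second aromatic ring.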